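Hydrogen to methyl on the aromatic ring: working notes

The compounds below may be only part of what the source reports. "The series", "measured", "known", "first", "only" and "open" are said of these compounds alone.

Compound 1 `Cc1cc(CNC(=O)Nc2cc(OCC(O)CO)nc(C(F)(F)F)c2)nnc1-c1cn(C)nc1C(F)(F)F`: in a functional assay on CHO cells for agonist activity at sphingosine 1-phosphate receptor 2 (Homo sapiens), read by fluorescence and calcium flux, with a stated time of 3 min (a lower number here means a stronger inhibitor, a higher number a weaker inhibitor), compound 1 gives < 3000 nM, a limit of the assay.
Compound 2 `Cc1cc(CNC(=O)Nc2cc(OCCO)nc(C(F)(F)F)c2)nnc1-c1cn(C)nc1C(F)(F)F`: in this assay compound 2 gives 4000 nM.

Among the compounds with values here, compound 2 holds the only number in the set. The value of compound 1 is a limit, (the limit of < 3000 nM in this assay, at which 1 of the 2 values shown sits). Within the data shown here, the one measured step, an at least 1.3-fold higher number from compound 1 to compound 2 (0.12 log units; that floor lies within the scatter), lies within the scatter. Compound 3 `Cc1cc(CNC(=O)Nc2cc(C(F)(F)F)nc(OCCO)c2C)nnc1-c1cn(C)nc1C(F)(F)F` differs from compound 2 by methyl in place of hydrogen on an aromatic carbon. Among the measured compounds shown here, no measured step touches an aromatic hydrogen, so no direct guide exists for it. For compound 3 the expected step of no change at the digits printed from compound 2 to compound 3 (within the scatter) is none beyond the scatter. The estimate for compound 3 in this assay is 4000 nM, with a range from 1500 nM to 10000 nM.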

Compound 3, half-maximal inhibitory concentration: 4400 nM
Compound 3: middle estimate off by 1.1-fold (0.04 log units), on the low side, within the range that was stated.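

In this assay, methyl in place of hydrogen on this aromatic carbon, ortho to a 2-hydroxyethoxy group and para to a trifluoromethyl group, gives a 1.1-fold higher number from compound 2 to compound 3 (0.04 log units; within the scatter). Within the data shown here, this is the first reading of a change on an aromatic carbon, and the step at this position stays within the scatter. Nothing measured here bears on the reason for this outcome.

Still open, going by these compounds, is whether a group other than methyl at this aromatic carbon, such as an amine, a methoxy group or a chlorine atom, would also leave the number within the scatter.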